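A Fluorine Step Repeated on a Dibromo Core

A few compounds are considered here, and "the series" means these few. Any claim that something is new, unique, unknown or untested is made for them only; others in the source may bear on it.

Compound 1 `COc1ccc2c(C3(c4c[nH]c5cc(OC)ccc45)C(=O)Nc4ccccc43)c[nH]c2c1` and compound 2 `O=C1Nc2ccccc2C1(c1c[nH]c2ccc(Br)cc12)c1c[nH]c2ccc(Br)cc12` are built on related cores, but the difference between the two cores is not broken down here. In a functional assay on DU-145 cells (Homo sapiens) for cytotoxicity, read by MTT assay, with a stated time of 48 h (a higher number here means a weaker inhibitor, a lower number a stronger inhibitor), compound 1 gives 1200 nM, while compound 2 gives 3600 nM. Compound 3 `COc1ccc2c(C3(c4c[nH]c5cc(OC)ccc45)C(=O)Nc4ccc(F)cc43)c[nH]c2c1` differs from compound 1 by fluoro in place of hydrogen on an aromatic carbon; in this assay compound 3 gives 13100 nM, and this change made a step of an 11-fold higher number from compound 1 to compound 3 (1.04 log units; beyond the scatter). Compound 4 `O=C1Nc2ccc(F)cc2C1(c1c[nH]c2ccc(Br)cc12)c1c[nH]c2ccc(Br)cc12` carries the same change relative to compound 2, namely (fluoro in place of hydrogen on an aromatic carbon), at a place described in identical terms. Because that change gave an 11-fold higher number from compound 1 to compound 3 (1.04 log units; beyond the scatter) once, a step in the same direction and of comparable size is expected here, a 6.9-fold higher number from compound 2 to compound 4 (0.84 log units; beyond the scatter), though a single precedent leaves the size uncertain. Compound 4 is therefore estimated at 25000 nM in this assay, with a likely range from 8000 nM to 80000 nM.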

Compound 4, half-maximal inhibitory concentration: 16300 nM
Beside the measured number, compound 4's estimate is 1.5-fold (0.19 log units) above it; the range from low to high includes it.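

In this assay, fluoro in place of hydrogen on the aromatic carbon again weakened the compound, giving a 4.5-fold higher number from compound 2 to compound 4 (0.66 log units; beyond the scatter). Both cores moved in the same direction, and the two step sizes cannot be told apart: the same change on two cores in this assay, an 11-fold higher number (1.04 log units; beyond the scatter) from compound 1 to compound 3 and a 4.5-fold higher number (0.66 log units; beyond the scatter) from compound 2 to compound 4, 2.4-fold (0.38 log units) apart, within the scatter of two such steps. This supports carrying the change between these two cores, but two pairs in one cell assay do not show that it would hold on any other core, nor do they explain why the number rises.

The compounds shown leave open what chloro, methyl or an amine would do at the same place. They also leave open whether the pattern extends to cell lines other than this one.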